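Trimming a benzyl to a phenyl on the shared core

The compounds below may be only part of what the source reports. "The series", "measured", "known", "first", "only" and "open" are said of these compounds alone.

Of the compounds shown here, two have been measured in a functional assay on FM3A cells (Mus musculus) for inhibition, read by cell counting, with a stated time of 2 days; on this read-out higher numbers stand for weaker inhibition and lower numbers for stronger inhibition. Compound 1 `CCc1ccc(-c2nn3cc(-c4cccc(N)c4)nc3s2)cc1` gives 8200 nM, and compound 2 `Nc1cccc(-c2cn3nc(Cc4ccccc4)sc3n2)c1` gives 4700 nM. Compound 2 has the lower of the two numbers, but the gap to compound 1 lies within the scatter, so no order can be read from it. Compound 3 `Nc1cccc(-c2cn3nc(-c4ccccc4)sc3n2)c1` differs from compound 2 in one place: phenyl in place of benzyl on an aromatic carbon. For the measured compounds named here, no comparable step has been measured here, so the expected change a 1.0-fold lower number from compound 2 to compound 3 (0.02 log units; within the scatter) is small and not beyond the scatter. Compound 3 is therefore estimated at 4500 nM, between 1500 nM and 13000 nM.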

Compound 3, half-maximal inhibitory concentration: 14000 nM
Estimate against measurement, compound 3: 3.1-fold (0.49 log units) below, outside the stated range (above it).
By their numbers in this assay, from the lowest: compounds 2, 1 and 3 (each within the scatter of the next, the first and the last beyond it).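

In this assay, phenyl in place of benzyl on this aromatic carbon gives a 3.0-fold higher number from compound 2 to compound 3 (0.47 log units; beyond the scatter), a modest step showing that the number at this position can respond to a small change in the group attached. Hydrogen in place of ethyl on an aromatic carbon gives a 1.7-fold higher number from compound 1 to compound 3 (0.23 log units; within the scatter), so that ethyl makes no readable difference. Nothing available explains either step.

As far as these compounds go, whether a phenethyl group or an amine on the same carbon would give a lower or a higher number remains open.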